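This account rests on a few compounds, and the source may have more. Where it says the series, first, only, none or still open, it means among the compounds named here.

Series notes in a functional assay for inhibition, with Homo sapiens as the target; on this read-out lower numbers stand for stronger inhibition and higher numbers for weaker inhibition. Compound 1 `CCc1nnc(O)n2c(C)nc(C)c12` gives > 48000 nM, which is a limit of the assay. Compound 2 `CCCc1nc(C)c2c(C(C)C)nnc(S)n12` likewise gives > 48000 nM, again a limit of the assay. Among the measured compounds shown here, compound 3 `CCCc1nc(C)c2c(CC)nnc(O)n12` gives 15600 nM, the only number in the set. Compound 1 and compound 2 show limits, and the limit of > 48000 nM in this assay, at which 2 of the 3 values shown sit, marks where they sit. For the measured compounds named here, the single measured step, an at least 3.0-fold lower number from compound 1 to compound 3 (0.48 log units; beyond the scatter), is the only comparison available. Compound 4 `CCCc1nc(C)c2c(CC)nnc(S)n12` differs from compound 3 by sulfanyl in place of hydroxy on an aromatic carbon. Going by the values given here, no measured step covers this exchange; compound 2, which also carries sulfanyl, shows only a limit and differs from compound 3 in two places, so it yields no step. The step of a 2.2-fold higher number from compound 3 to compound 4 (0.35 log units; beyond the scatter) is therefore expected to be small or none beyond the scatter, with a fair chance of another limit. Compound 4 is estimated at 35000 nM, within 12000 nM to 100000 nM.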

Compound 4, half-maximal inhibitory concentration: > 48000 nM
Compound 4: a limit, no number; the forecaster's own chance of this, stated with the estimate: 55%; middle value at least 1.3-fold (0.13 log units) away from the limit.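

In this assay, among the compounds shown here, sulfanyl in place of hydroxy on this aromatic carbon between two ring nitrogen atoms gives the first readable step at this position: an at least 3.0-fold higher number from compound 3 to compound 4 (0.48 log units; beyond the scatter) and this size is only a floor. Compound 2 and compound 4 both show limits, and the step between them cannot be read. Hydroxy remains the only group at this position with a number, and most of the series gives none: the limit of > 48000 nM in this assay, at which 3 of the 4 values shown sit.

Going by these compounds, whether an amine or a methoxy group at this position would give a number stays open. Also open, on these data alone, is whether a longer chain in place of the ethyl group would shift the value of the hydroxy compound.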